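The source may report more compounds than this note shows. Statements on the series, on what has been measured and on what is new or still open speak of the compounds shown alone.

In an ADME assay on BaF3 cells (Mus musculus) for cytotoxicity, read by CellTiter-Glo and CCK-8 assay, with a stated time of 72 h (on this read-out lower numbers stand for stronger inhibition of growth and higher numbers for weaker inhibition of growth), three compounds sharing one core have been read. Compound 1, `C=CC(=O)NCc1cccc(C(=O)Nc2ccc(C)c(Nc3nccc(-c4cccnc4)n3)c2)c1`, gives > 10000 nM, which is a limit of the assay. Compound 2, `CCC(=O)Nc1ccc(C(=O)Nc2ccc(C)c(Nc3nccc(-c4cccnc4)n3)c2)cc1`, gives > 10000 nM, again a limit. Among the measured compounds shown here, compound 3, `C=CC(=O)Nc1ccc(C(=O)Nc2ccc(C)c(Nc3nccc(-c4cccnc4)n3)c2)cc1`, gives 5600 nM, the only actual number of the three. The other two values rest on (the limit of > 10000 nM in this assay, at which 2 of the 3 values shown sit). For the measured compounds named here, the single measured step, an at least 1.7-fold lower number from compound 2 to compound 3 (0.25 log units; that floor lies within the scatter), has a floor within the scatter, so it gives only weak guidance.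

Compound 4, `C=CC(=O)Nc1cccc(C(=O)Nc2ccc(C)c(Nc3nccc(-c4cccnc4)n3)c2)c1`, differs from compound 3 by 3-((vinylcarbonyl)amino)phenyl in place of 4-((vinylcarbonyl)amino)phenyl on a carbonyl carbon, with 3-((vinylcarbonyl)amino)phenyl in place of 4-((vinylcarbonyl)amino)phenyl on a carbonyl carbon. Going by the values given here, no measured step makes this exchange, and the step from compound 2 concerns only the vinyl in place of ethyl, which compound 4 keeps. The expectation therefore starts from compound 3 at 5600 nM, with no change beyond the scatter foreseen. A result at the limit of the assay is also expected to be quite possible for compound 4. The expected size of the change is a 1.4-fold higher number from compound 3 to compound 4 (0.15 log units; within the scatter). The estimate for compound 4 is 8000 nM, within an expected range of 3000 nM to 15000 nM.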

Compound 4, concentration for 50% growth inhibition: 2480 nM
Compound 4: middle estimate off by 3.2-fold (0.51 log units), on the high side; the whole stated range lies above it.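

In this assay, 3-((vinylcarbonyl)amino)phenyl in place of 4-((vinylcarbonyl)amino)phenyl on the carbonyl carbon gives a 2.3-fold lower number from compound 3 to compound 4 (0.35 log units; beyond the scatter), so with the same atoms joined differently, this exchange moves the read-out beyond the scatter towards stronger inhibition of growth. Placing (vinylcarbonyl)amino in place of ((vinylcarbonyl)amino)methyl on an aromatic carbon gives an at least 4.0-fold lower number from compound 1 to compound 4 (0.60 log units; beyond the scatter), and 3-((vinylcarbonyl)amino)phenyl in place of 4-(propanoylamino)phenyl gives an at least 4.0-fold lower number from compound 2 to compound 4 (0.60 log units; beyond the scatter). These two steps are floors beyond the scatter, each starting from a limit: the limit of > 10000 nM in this assay, at which 2 of the 4 values shown sit.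

Going by these compounds, whether the vinyl is needed with this arrangement remains open, since a reading for 3-(propanoylamino)phenyl would be required to separate the two changes. On these data alone, how a plain 3-aminophenyl or a longer acyl chain would read also remains open.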